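The source may hold more compounds than are shown below. What is called first, only, known or untested is meant among the compounds shown, and "the series" means these compounds.

Measured in a functional assay on a cell-free system (Platelet, plasma, Homo sapiens) for inhibition; on this read-out lower numbers stand for stronger inhibition and higher numbers for weaker inhibition:
Compound 1 `O=C(O)CCN1Cc2ccc(NC(=O)c3ccc(C4CCNCC4)cc3)cc2C1=O` gives 9600 nM.
Compound 2 `O=C(O)CCCN1Cc2ccc(NC(=O)CCCC3CCNCC3)cc2C1=O` gives 51000 nM.
Compound 3 `O=C(O)CCN1Cc2ccc(NC(=O)c3ccc(N4CCNCC4)cc3)cc2C1=O` gives 540 nM.

Compound 3 stands lowest of the three numbers. Going by the values given here, the only single-point step in this set, an 18-fold lower number from compound 1 to compound 3 (1.25 log units; beyond the scatter), swaps one ring for another on the aromatic carbon, and compound 2 differs from compound 3 in several places at once, so its value says nothing on its own about one change.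

Compound 4 `O=C(O)CN1Cc2ccc(NC(=O)c3ccc(N4CCNCC4)cc3)cc2C1=O` differs from compound 3 in one place: carboxy in place of carboxymethyl on a saturated chain carbon bound to an amide-type nitrogen in a ring. Among the compounds with values here, no measured step touches this acid chain, so nothing here points in either direction. The expectation is therefore a step of about a 1.7-fold higher number from compound 3 to compound 4 (0.22 log units; within the scatter) in this assay, likely within the scatter. Compound 4 is estimated at 900 nM, with a range from 200 nM to 4000 nM.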

Compound 4, half-maximal inhibitory concentration: 3300 nM
Beside the measured number, compound 4's estimate is 3.7-fold (0.56 log units) below it, within the range that was stated.
By their numbers in this assay, from the lowest: compound 3; then compound 4; then compound 1; then compound 2.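

Moving from 2-carboxyethyl to carboxymethyl gives a 6.1-fold higher number from compound 3 to compound 4 (0.79 log units; beyond the scatter) in this assay. The earlier step concerned only the ring on the aromatic carbon, whereas this one shows that the length of the acid chain also matters, with the shorter chain giving weaker inhibition in this pair. Nothing available explains this difference.

As far as these compounds go, only these two chain lengths can be compared on this core, so it remains open whether a 3-carboxypropyl chain would continue the trend. From the compounds shown here alone, the effect of replacing the carboxylic acid with a primary amide or a methyl ester also remains unknown.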